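From chloro to bromo: one halogen swap

This account rests on a few compounds, and the source may have more. Where it says the series, first, only, none or still open, it means among the compounds named here.

Measured so far in a functional assay on OVCAR-5 cells (Homo sapiens) for inhibition; on this read-out lower numbers stand for stronger inhibition of growth and higher numbers for weaker inhibition of growth (all three below)
- Compound 1 `Nc1ccc(-c2nc3ccc(F)cc3s2)cc1I` gives 100 nM as a number
- Compound 2 `Nc1ccc(-c2nc3cc(F)ccc3s2)cc1Cl` gives < 10 nM as a limit
- Compound 3 `Nc1ccc(-c2nc3ccccc3s2)cc1F` gives < 10 nM as a limit

Compound 2 sits at the limit of < 10 nM in this assay, at which 2 of the 3 values shown sit, and so carries a limit, not a number. Compound 4 `Nc1ccc(-c2nc3cc(F)ccc3s2)cc1Br` has bromo in place of chloro on an aromatic carbon, ortho to an amino group (bromo in place of chloro on an aromatic carbon). For the measured compounds named here, no measured pair isolates this swap. Compound 1 carries iodo and gives 100 nM but differs from compound 2 in more than one place, so it is only a loose warning. No change beyond the usual scatter is expected in this assay, and the estimated step is a step that the limit leaves unreadable from compound 2 to compound 4 in size. Compound 4 is expected at 8 nM (estimated range 2 nM to 40 nM).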

Compound 4, concentration for 50% growth inhibition: 50 nM
Estimate against measurement, compound 4: 6.3-fold (0.80 log units) below, outside the stated range (above it).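

In this assay, for the compounds shown here, bromo in place of chloro, ortho to an amino group, gives an at least 5.0-fold higher number from compound 2 to compound 4 (0.69 log units; beyond the scatter), so this one swap is enough to weaken growth inhibition, something no earlier pair could isolate. The two halogens are therefore not interchangeable at this place on the shared core. The step is only a minimum because compound 2 carries a limit, not a number: the limit of < 10 nM in this assay, at which 2 of the 4 values shown sit.

A methyl or methoxy group at this place remains untested among the compounds shown. So does iodo on the exact core of compound 2.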